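Adding a Benzoyl Group: Expected Effect on Peroxidase Inhibition

This account rests on a few compounds, and the source may have more. Where it says the series, first, only, none or still open, it means among the compounds named here.

Compound 1 `S=C(Nc1ccccc1)Nc1ccc2[nH]ccc2c1` carries the shared core with an unsubstituted phenyl end. For the measured compounds named here, in an ADME assay on isolated protein for inhibition of peroxidase (Raphanus sativus), read by fluorescence and Amplex Red, tested at 5 uM (a higher number here means a weaker effect of the compound at the concentration tested, a lower number a stronger effect), compound 1 gives 81.4%, the highest of the three numbers measured so far. Compound 2 `Oc1ccc(NC(=S)Nc2ccc3[nH]ccc3c2)cc1`, which bears a hydroxy in place of hydrogen on an aromatic carbon, gives 41.5% in this assay, and compound 3 `S=C(Nc1ccc(Oc2ccccc2)cc1)Nc1ccc2[nH]ccc2c1`, with a phenoxy in place of hydrogen on an aromatic carbon, gives 73.1%. The step of a number 39.9 percentage points lower from compound 1 to compound 2 (beyond the scatter) is large, while the step of a number 8.3 percentage points lower from compound 1 to compound 3 (within the scatter) stays within the scatter, and the step of a number 31.6 percentage points higher from compound 2 to compound 3 (beyond the scatter) is again large.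

Compound 4 `O=C(c1ccccc1)c1ccc(NC(=S)Nc2ccc3[nH]ccc3c2)cc1` differs from compound 1 by benzoyl in place of hydrogen on an aromatic carbon. The entering group, like phenoxy, brings one six-membered aromatic ring of carbon only and no hydrogen-bond donor, so the step to compound 3 is the closer guide, whereas the step to compound 2 shows what a small hydroxy did instead. The step expected is therefore modest, a number 11.4 percentage points lower from compound 1 to compound 4 (beyond the scatter), somewhat lower but probably within the scatter. Compound 4 is estimated at 70%, with a range between 45% and 90%.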

Compound 4, a percentage reported as activity, at one concentration (the size of the read-out at that concentration, not a potency): 79.1%
For compound 4 the middle estimate is 9.1 percentage points below the measured one, within the range that was stated.
By their numbers in this assay, from the lowest: compound 2; then compounds 3, 4 and 1 (each within the scatter of the next).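

At this place on the aromatic carbon, para to a large group, benzoyl now joins phenoxy as a second entering group with a six-membered aromatic ring that leaves the read-out in this assay close to that of the unsubstituted phenyl end, with benzoyl in place of hydrogen giving a number 2.3 percentage points lower from compound 1 to compound 4 (within the scatter) and benzoyl in place of phenoxy giving a number 6 percentage points higher from compound 3 to compound 4 (within the scatter). Among these four compounds, then, swapping the carbonyl-linked ring for the oxygen-linked ring makes no difference that can be told from scatter, and compound 2 goes against any flat picture of this position, as benzoyl in place of hydroxy gives a number 37.6 percentage points higher from compound 2 to compound 4 (beyond the scatter) and this large step sets hydroxy apart. No measurement at hand accounts for why hydroxy stands apart from the two ring-bearing groups.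

Still open, on these data alone, is whether the large step belongs to hydroxy alone or would also appear with another small group at this place, such as methoxy, an amine or a carboxylic acid. Also open, as far as these compounds go, is how a longer chain between the ring and this position would read in the same assay.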